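Bromo for Fluoro on the Shared Core

The source may report more compounds than this note shows. Statements on the series, on what has been measured and on what is new or still open speak of the compounds shown alone.

Compound 1 `COc1ccc(-c2cn3ccnc3c(-c3ccc4ncn(C5CCCCC5)c4c3)n2)cc1`: -26.5%
Compound 2 `O=Cc1ccc(-c2cn3ccnc3c(-c3ccc4ncn(C5CCCCC5)c4c3)n2)cc1`: 23.7%
Compound 3 `Fc1ccc(-c2cn3ccnc3c(-c3ccc4ncn(C5CCCCC5)c4c3)n2)cc1`: 7.88%

In a functional assay on OVCAR-3 cells (Homo sapiens) for inhibition, read by sulforhodamine B assay, with a stated time of 48 h, tested at 10 uM (on this read-out higher numbers stand for more inhibition at the one concentration tested (going by the name of the read-out) and lower numbers for less inhibition), compound 3 stands second highest of the three values: the step of a number 15.8 percentage points lower from compound 2 to compound 3 (beyond the scatter) separates it from compound 2, and the step of a number 34.4 percentage points higher from compound 1 to compound 3 (beyond the scatter) separates it from compound 1. Compound 4 `Brc1ccc(-c2cn3ccnc3c(-c3ccc4ncn(C5CCCCC5)c4c3)n2)cc1` differs from compound 3 by bromo in place of fluoro on an aromatic carbon. For the measured compounds named here, no measured step exchanges one halogen for another; the steps that touch fluoro, a number 34.4 percentage points higher from compound 1 to compound 3 (beyond the scatter) and a number 15.8 percentage points lower from compound 2 to compound 3 (beyond the scatter), and the large step of a number 50.2 percentage points higher from compound 1 to compound 2 (beyond the scatter) all replace groups of a different kind, so they bear only loosely on this change. A small step in this assay, possibly none beyond the scatter, is therefore expected. Compound 4 is estimated at 15%, between -15% and 45%. The expected step is a number 7.1 percentage points higher from compound 3 to compound 4 (within the scatter).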

Compound 4, a percentage reported as inhibition, at one concentration (the size of the read-out at that concentration, not a potency): 26.3%
Compound 4: middle estimate off by 11.3 percentage points, on the low side, and the stated range covers the measured number.
By their numbers in this assay, from the lowest: compound 1; then compound 3; then compounds 2 and 4 (each within the scatter of the next).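

In this assay, the exchange of one halogen for another at this place is not silent: going from 4-fluorophenyl to 4-bromophenyl gives (a number 18.4 percentage points higher from compound 3 to compound 4 (beyond the scatter)). Bromo also stands far from methoxy (a number 52.8 percentage points higher from compound 1 to compound 4 (beyond the scatter)) but cannot be told apart from formyl (a number 2.6 percentage points higher from compound 2 to compound 4 (within the scatter)). No evidence is available on what lies behind the difference between the two halogens.

The compounds shown leave open where chloro would fall relative to fluoro and bromo. They also leave open how an amine or a carboxylic acid on this aromatic carbon would read.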